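This account rests on a few compounds, and the source may have more. Where it says the series, first, only, none or still open, it means among the compounds named here.

Measured so far in an assay on membranes from HEK293 cells for displacement of a labelled ligand from adenosine receptor A2b (Homo sapiens), read by scintillation counting, with a stated time of 30 min, tested at 1 uM; on this read-out higher numbers stand for more inhibition at the one concentration tested (going by the name of the read-out) and lower numbers for less inhibition:

compound 1, `CCNC(=O)C1=C(C)NC(=O)NC1c1cccs1`: 1%
compound 2, `CCN(CC)C(=O)C1=C(C)NC(=O)NC1c1cccs1`: 22%
compound 3, `CC1=C(C(N)=O)C(c2ccsc2)NC(=O)N1`: 1%

Compound 1 and compound 2 share a core and differ only by ethyl in place of hydrogen on an amide-type nitrogen; this gave a number 21 percentage points higher from compound 1 to compound 2 (beyond the scatter). Compound 3 stands level with compound 1 at the digits printed, and the two together sit lowest of the three numbers; against compound 2 it lies lower, beyond the scatter. The difference between the core of compound 3 and the core of compound 1 is not broken down here.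

Compound 4, `CCNC(=O)C1=C(C)NC(=O)NC1c1ccsc1`, is not yet measured. It differs from compound 3 by ethyl in place of hydrogen on an amide-type nitrogen. This is the same kind of change as that from compound 1 to compound 2, but not the same: in the earlier pair the amide-type nitrogen carried, besides the entering ethyl, a carbonyl carbon and a saturated chain carbon, whereas in compound 3 its other neighbour is only the carbonyl carbon.

For the measured compounds named here, the sole measured step of this kind, from compound 1 to compound 2, was modest. For compound 4 a smaller rise is expected, since compound 1, which already carries the ethylcarbamoyl on its own core, gives only 1% in this assay. The step from compound 3 to compound 4 is estimated as a number 4 percentage points higher from compound 3 to compound 4 (within the scatter). Compound 4 is therefore expected to give about 5%, between 0% and 20%.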

Compound 4, a percentage reported as inhibition, at one concentration (the size of the read-out at that concentration, not a potency): 1%
Beside the measured number, compound 4's estimate is 4 percentage points above it, within the range that was stated.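

In this assay, ethyl in place of hydrogen on an amide-type nitrogen does not carry over as one fixed step from one core to the other: the same change on two cores in this assay, a number 21 percentage points higher (beyond the scatter) from compound 1 to compound 2 and no change at the digits printed (within the scatter) from compound 3 to compound 4, 21 percentage points apart, beyond the scatter of two such steps. On the new pair the reading is no change at the digits printed from compound 3 to compound 4 (within the scatter), and thiophen-3-yl in place of thiophen-2-yl on a saturated ring carbon gives no change at the digits printed from compound 1 to compound 4 (within the scatter). This does not show what separates the two ethyl steps, since the amide-type nitrogen of compound 1 already carries a saturated chain carbon, whereas in compound 3 its other neighbour is only the carbonyl carbon, and the thiophene attachment differs as well.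

Open, as far as these compounds go, is whether a second ethyl on the amide-type nitrogen of compound 4 would repeat the rise seen with compound 2, a comparison that would set the thiophene attachment apart from the nitrogen's neighbours. Also open, from the compounds shown here alone, is how a longer chain such as propyl on that nitrogen, or a phenyl in place of the thiophene, would read in this assay.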